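This account rests on a few compounds, and the source may have more. Where it says the series, first, only, none or still open, it means among the compounds named here.

Compound 1 `CC(C)Cc1ccc2c(NCCCNCc3ccco3)ccnc2c1` was tested in an ADME assay on HepG2 cells (Homo sapiens) for cytotoxicity, read by luminescence, CellTiter-Glo and ATP content, with a stated time of 72 h (a higher number here means that more compound is needed for the effect, a lower number that less compound is needed), and gives 16000 nM. Among the three measured compounds, compound 1 stands highest: compound 2 `CCC(CC)c1ccc2c(NCCCNCc3cccc(OC)c3O)ccnc2c1` gives 410 nM, far below it and beyond the scatter, and compound 3 `COc1ccc(F)cc1CNCCCNc1ccnc2cc(CCc3ccccc3)ccc12` gives 4240 nM, also beyond the scatter below compound 1. Compound 4 `c1coc(CNCCCNc2ccnc3cc(C4CCCCC4)ccc23)c1` has not been measured in this assay. It differs from compound 1 in one place: cyclohexyl in place of isobutyl on an aromatic carbon. Among the measured compounds shown here, no pair of measured compounds differs in only one place, so this step has no measured counterpart. For compound 4 the expected step is a 2.7-fold lower number from compound 1 to compound 4 (0.43 log units; beyond the scatter), downward and beyond the scatter, yet smaller than the gap from compound 1 down to compound 2. Compound 4 is accordingly estimated at 6000 nM, with a range from 2000 nM to 18000 nM.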

Compound 4, half-maximal effective concentration: 4760 nM
Estimate against measurement, compound 4: 1.3-fold (0.10 log units) above, and the stated range covers the measured number.
By their numbers in this assay, from the lowest: compound 2; then compounds 3 and 4 (each within the scatter of the next); then compound 1.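

Among the compounds shown here, at this position, on an aromatic carbon of the shared core, the earlier compounds gave no comparison in one place, whereas cyclohexyl in place of isobutyl now gives a 3.4-fold lower number from compound 1 to compound 4 (0.53 log units; beyond the scatter) in this assay with the rest of the structure unchanged. The number therefore responds to the group at this position alone, and the ring with its larger carbon count lies on the lower side. Nothing measured here gives a reason for this step.

Whether ring closure or carbon count matters cannot be separated, and an open hexyl chain would bear on that. From the compounds shown here alone, how phenyl or an amine at this position would behave remains open.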